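Swapping the Urea Aryl Group: Chlorophenyl to Methylphenyl

A few compounds are considered here, and "the series" means these few. Any claim that something is new, unique, unknown or untested is made for them only; others in the source may bear on it.

Compound 2 `CN(C)CCCNc1nc(-c2ccc(NC(=O)Nc3ccccc3Cl)cc2)nc2c(Cl)c(Cl)sc12` is one of three urea-bearing analogues tested in a functional assay on MDA-MB-231 cells (Homo sapiens) for cytotoxicity, read by MTT assay, with a stated time of 72 h; on this read-out lower numbers stand for stronger inhibition and higher numbers for weaker inhibition. In this assay compound 2 gives 1560 nM; compound 3 `CN(C)CCNc1nc(-c2ccc(NC(=O)Nc3ccccc3)cc2)nc2ccsc12` gives 1310 nM and compound 1 `CN(C)CCCNc1nc(-c2ccc(NC(=O)Nc3ccc(F)cc3)cc2)nc2c(Cl)c(Cl)sc12` gives 980 nM, and both of those numbers lie within the scatter of compound 2, so the three cannot be separated. Compound 4 `Cc1ccc(NC(=O)Nc2ccc(-c3nc(NCCCN(C)C)c4sc(Cl)c(Cl)c4n3)cc2)cc1` differs from compound 2 by 4-methylphenyl in place of 2-chlorophenyl on an amide-type nitrogen. For the measured compounds named here, the only measured step at this position is a 1.6-fold higher number from compound 1 to compound 2 (0.20 log units; within the scatter), which stayed within the scatter; no step involving a 4-methylphenyl group has been measured. The expectation for compound 4 is therefore a step no larger than the scatter, a 1.2-fold lower number from compound 2 to compound 4 (0.08 log units; within the scatter). Compound 4 is thus estimated at 1300 nM, with a range from 650 nM to 2600 nM.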

Compound 4, half-maximal inhibitory concentration: 4980 nM
The estimate for compound 4 lay 3.8-fold (0.58 log units) below the measured number, outside the stated range (above it).
By their numbers in this assay, from the lowest: compounds 1, 3 and 2 (each within the scatter of the next); then compound 4.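

For the compounds shown here, the urea aryl group can matter after all: in this assay the change to 4-methylphenyl gives a step beyond the scatter (a 3.2-fold higher number from compound 2 to compound 4 (0.50 log units; beyond the scatter)), unlike the one earlier step here (a 1.6-fold higher number from compound 1 to compound 2 (0.20 log units; within the scatter)). Methyl in place of fluoro on an aromatic carbon moves the number the same way (a 5.1-fold higher number from compound 1 to compound 4 (0.71 log units; beyond the scatter)), so compound 4 stands apart from both halogen-bearing compounds. No data at hand explain this difference. Still open, going by these compounds, is whether a methoxy group or an amine on this aryl ring would behave like the chloro of compound 2 and the fluoro of compound 1, or like the methyl of compound 4.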